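Aryl exchange on the shared core: compound 2 to compound 3

The compounds below may be only part of what the source reports. "The series", "measured", "known", "first", "only" and "open" are said of these compounds alone.

Measured compounds:
compound 1 `Cc1cccc(-c2cc(-c3ccc(Cl)o3)cc(-c3ccsc3)n2)c1` – 20200 nM
compound 2 `Clc1ccc(-c2cc(-c3ccsc3)nc(-c3ccccn3)c2)o1` – 21900 nM

Both numbers come from a functional assay on K562 cells (Homo sapiens) for cytotoxicity, in the presence of a further agent that is not named here; a higher number here means a weaker inhibitor, a lower number a stronger inhibitor. For the measured compounds named here, compound 1 gives 20200 nM and compound 2 gives 21900 nM; the step of a 1.1-fold higher number from compound 1 to compound 2 (0.04 log units; within the scatter) lies within the scatter, so compound 2 and compound 1 cannot be told apart on these numbers, and compound 2 simply sits with the only other value of the series.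

Compound 3 `Clc1cccc(-c2cc(-c3ccc(Cl)o3)cc(-c3ccsc3)n2)c1` differs from compound 2 in one place: 3-chlorophenyl in place of pyridin-2-yl on an aromatic carbon. Going by the values given here, the one measured step, a 1.1-fold higher number from compound 1 to compound 2 (0.04 log units; within the scatter), put pyridin-2-yl where 3-methylphenyl had been on the same aromatic carbon and stayed within the scatter. Among the compounds with values here, compound 3 moves back towards a carbon-only ring, 3-chlorophenyl, but no measured step shows chlorine on that ring. Because a 1.1-fold higher number from compound 1 to compound 2 (0.04 log units; within the scatter) was within the scatter, compound 3 is expected to give 19000 nM (range 9000 nM to 40000 nM). The expected step is a 1.2-fold lower number from compound 2 to compound 3 (0.06 log units; within the scatter), none beyond the scatter.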

Compound 3, half-maximal inhibitory concentration: 23000 nM
Compound 3: middle estimate off by 1.2-fold (0.08 log units), on the low side; the measured number falls inside the stated range.
By their numbers in this assay, from the lowest: compounds 1, 2 and 3 (each within the scatter of the next).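

In this assay, 3-chlorophenyl in place of pyridin-2-yl on the aromatic carbon next to the ring nitrogen gives a 1.1-fold higher number from compound 2 to compound 3 (0.02 log units; within the scatter), so this exchange of aryl groups leaves the read-out unresolved. Chloro in place of methyl on the phenyl ring gives a 1.1-fold higher number from compound 1 to compound 3 (0.06 log units; within the scatter), the first direct comparison of two substituents on that ring, and compound 1 and compound 3 cannot be told apart. No independent measurement bears on these results.

Going by these compounds, the three aryl groups at this position show no measurable difference, so it remains open whether an amine or a carboxylic acid on that ring would shift the number. Also open, on these data alone, is the contribution of the 5-chlorofuran-2-yl and thiophen-3-yl groups, which stay the same in compound 1, compound 2 and compound 3.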